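Swapping an Aromatic Ring for a Saturated One

This account rests on a few compounds, and the source may have more. Where it says the series, first, only, none or still open, it means among the compounds named here.

In a functional assay on SH-SY5Y cells (Homo sapiens), read by MTT assay, with a stated time of 24 h (a lower number here means that less compound is needed, a higher number that more compound is needed for the effect), compound 2 `COc1ccccc1NC(=O)CN(c1cc(Cl)ccc1OC)S(=O)(=O)c1ccccc1` gives 15500 nM, the highest of the two numbers measured here. Compound 1 `CCn1ccc2cc(NC(=O)CN(c3cc(Cl)ccc3OC)S(=O)(=O)c3ccccc3)ccc21` gives 2220 nM, and the step of a 7.0-fold higher number from compound 1 to compound 2 (0.84 log units; beyond the scatter) shows that the group on the amide-type nitrogen can shift the number clearly. Compound 3 `COc1ccc(Cl)cc1N(CC(=O)NC1CCCCC1)S(=O)(=O)c1ccccc1` carries the change (cyclohexyl in place of 2-methoxyphenyl on an amide-type nitrogen). Among the compounds with values here, only that one measured step touches the same position, and it concerns a different pair of groups, so it is a rough guide at best. Compound 3 is therefore expected to give about 12000 nM, between 3000 nM and 50000 nM, an expected step of a 1.3-fold lower number from compound 2 to compound 3 (0.11 log units; within the scatter).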

Compound 3, half-maximal effective concentration: 17600 nM
Estimate against measurement, compound 3: 1.5-fold (0.17 log units) below; low and high end bracket the measured number.
By their numbers in this assay, from the lowest: compound 1; then compounds 2 and 3 (each within the scatter of the next).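

Replacing the aromatic 2-methoxyphenyl with the saturated cyclohexyl gives numbers that cannot be told apart, with a 1.1-fold higher number from compound 2 to compound 3 (0.06 log units; within the scatter) as the step. At this amide-type nitrogen, then, the aromatic ring of compound 2 offers no measurable advantage over the saturated ring of compound 3, while the 1-ethyl-1H-indol-5-yl group of compound 1 stands clearly apart, with a 7.9-fold higher number from compound 1 to compound 3 (0.90 log units; beyond the scatter) as the step. No measured evidence explains these numbers.
Still open, on these data alone, is how a much smaller group, such as methyl, or a saturated ring carrying an amine, such as piperidin-4-yl, would behave here.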